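Phenyl for Methyl on a Shared Core

The compounds below may be only part of what the source reports. "The series", "measured", "known", "first", "only" and "open" are said of these compounds alone.

Measured compounds in a functional assay on the whole organism for inhibition, with Mus musculus as the target, in the writhing test, with stated times of 30 min and 2 h, at a dose of 25 mg/kg by the intraperitoneal route; a lower number here means less inhibition, a higher number more inhibition at the dose given (going by the name of the read-out):
Compound 1 `CCOC(=O)c1nn(-c2ccc(Cl)cc2)c(-c2ccc(OC)cc2OC)c1C` gives 40%.
Compound 2 `COc1ccc(-c2c(C)c(C(=O)O)nn2-c2ccc(Cl)cc2)c(OC)c1` gives 20%.

Compound 2 stands lowest of the two numbers in this assay, with compound 1 the nearest, a step beyond the scatter. Among the compounds with values here, the only measured step, a number 20 percentage points lower from compound 1 to compound 2 (beyond the scatter), concerns a different part of the molecule. Compound 3 `COc1ccc(-c2c(-c3ccccc3)c(C(=O)O)nn2-c2ccc(Cl)cc2)c(OC)c1` differs from compound 2 by phenyl in place of methyl on an aromatic carbon. Within the data shown here, no measured step bears on this change, so the data give no direction for it; the step of a number 5 percentage points higher from compound 2 to compound 3 (within the scatter) is expected to lie within the scatter. Compound 3 is estimated at 25%, between 5% and 50%.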

Compound 3, a percentage reported as inhibition, in the whole organism at one dose (the size of the read-out at that dose, not a potency): 60%
Compound 3: the middle estimate sits 35 percentage points below what was measured; measured number outside the range, above it.
By their numbers in this assay, from the lowest: compound 2; then compound 1; then compound 3.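

This position matters in this assay: phenyl in place of methyl on this aromatic carbon, next to the ring atom that bears a carboxy group, gives a number 40 percentage points higher from compound 2 to compound 3 (beyond the scatter) on the shared core. Within the data shown here, the only earlier step concerned the ethyl on an oxygen next to a carbonyl group, so this is the first sign that the group on this carbon also moves the read-out. Nothing measured here explains the rise. Open, from the compounds shown here alone, is whether an amine or a longer chain on this carbon would give a similar number, and whether phenyl would give a similar rise with the ethyl ester of compound 1.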